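A few compounds are considered here, and "the series" means these few. Any claim that something is new, unique, unknown or untested is made for them only; others in the source may bear on it.

Compound 2 `Cc1cccc(-c2cnc(C(=O)CCCCCCc3ccccc3)o2)n1` is the stronger of the two compounds measured in an assay (Rattus norvegicus) for inhibition of Fatty-acid amide hydrolase 1 (Homo sapiens); a lower number here means a stronger inhibitor, a higher number a weaker inhibitor: compound 2 gives 3.3 nM, while compound 1 `O=C(CCCCCCc1ccccc1)c1ncc(-c2ccc(F)cc2)o1` gives 62 nM. Within the data shown here, the single measured step, a 19-fold lower number from compound 1 to compound 2 (1.27 log units; beyond the scatter), therefore shows that the group attached to the shared core can move the result a long way.

Compound 3 `O=C(CCCCCCc1ccccc1)c1ncc(-c2ccncn2)o1` differs from compound 2 by one change on an aromatic carbon of that core: pyrimidin-4-yl in place of 6-methylpyridin-2-yl on an aromatic carbon. Among the measured compounds shown here, no measured step covers this exact change; the only step at hand, a 19-fold lower number from compound 1 to compound 2 (1.27 log units; beyond the scatter), concerns a different swap, so it shows how sensitive this position is but not which way a second nitrogen and a lost methyl will pull. With the ring still being a nitrogen-bearing six-membered aromatic, compound 3 is expected to stay near compound 2, with a small step estimated as a 1.8-fold higher number from compound 2 to compound 3 (0.26 log units; within the scatter). For compound 3 the estimated value in this assay is 6 nM, expected to fall between 2 nM and 20 nM.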

Compound 3, inhibition constant: 2.3 nM
Beside the measured number, compound 3's estimate is 2.6-fold (0.42 log units) above it; the measured number falls inside the stated range.
By their numbers in this assay, from the lowest: compounds 3 and 2 (each within the scatter of the next); then compound 1.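

In this assay, the swap gives a 1.4-fold lower number from compound 2 to compound 3 (0.16 log units; within the scatter) and stays within the scatter, so this position tolerates losing the methyl and going from 1 hetero atom to 2 hetero atoms in the ring without a measurable shift. Replacing the 4-fluorophenyl gives a 27-fold lower number from compound 1 to compound 3 (1.43 log units; beyond the scatter) and is large, much like a 19-fold lower number from compound 1 to compound 2 (1.27 log units; beyond the scatter), so the earlier gain is not tied to one particular ring: two different nitrogen-bearing rings both reach low numbers. The data shown offer no independent measurement that could explain this shared result.

Going by these compounds, it remains open whether a plain phenyl or a pyridin-2-yl without the methyl would match these two rings, which would help separate the role of the ring nitrogen from that of the fluorine. On these data alone, how a carboxylic acid or an amine on the pyrimidin-4-yl ring would fare also stays unknown.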